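The source may report more compounds than this note shows. Statements on the series, on what has been measured and on what is new or still open speak of the compounds shown alone.

In a functional assay on HEK293 cells for antagonist activity at transient receptor potential cation channel subfamily V member 1 (Homo sapiens), read by FLIPR (a higher number here means a weaker inhibitor, a lower number a stronger inhibitor), compound 1 `O=C(Nc1cccc2cnccc12)NC1CCc2cc(F)ccc2C1Cc1ccccc1` gives 12 nM, and compound 2 `O=C(Nc1cccc2cnccc12)NC1CCc2cc(Br)ccc2C1Cc1ccccc1` gives 17 nM, so the two numbers sit within the scatter of each other, as the step of a 1.4-fold higher number from compound 1 to compound 2 (0.15 log units; within the scatter) shows. Compound 3 `O=C(Nc1cccc2cnccc12)NC1CCc2cc(F)ccc2C1Cc1ccc(C(F)(F)F)cc1` differs from compound 1 by trifluoromethyl in place of hydrogen on an aromatic carbon. For the measured compounds named here, the only measured step, the halogen swap from compound 1 to compound 2, concerns a different part of the molecule and stayed within the scatter, so it gives no direct guide to this change. Compound 3 is therefore expected to stay near the same level, with a 1.3-fold higher number from compound 1 to compound 3 (0.10 log units; within the scatter) and a wide range. The estimate for compound 3 is 15 nM, between 4 nM and 60 nM.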

Compound 3, half-maximal inhibitory concentration: 10 nM
For compound 3 the middle estimate is 1.5-fold (0.18 log units) above the measured one; low and high end bracket the measured number.
By their numbers in this assay, from the lowest: compounds 3, 1 and 2 (each within the scatter of the next).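

The benzyl group of compound 1 accepts a large addition on its aromatic ring: going from phenyl to 4-(trifluoromethyl)phenyl gives a 1.2-fold lower number from compound 1 to compound 3 (0.08 log units; within the scatter) in this assay. The earlier halogen swap said nothing about this ring, and here the added trifluoromethyl costs no measurable inhibition. No measurement shown explains this tolerance.

From the compounds shown here alone, whether an amine, a carboxylic acid or a methoxy group would be accepted at this same place stays open. So does whether trifluoromethyl would behave the same way on the bromo compound 2.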